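Swapping the Substituted Phenyl Ring of a Bradykinin Antagonist

The source may report more compounds than this note shows. Statements on the series, on what has been measured and on what is new or still open speak of the compounds shown alone.

Compound 1, `C[C@@H](Nc1nccc(Cl)c1NC(=O)CC#N)c1ccc(-c2cccc(F)c2C#N)cc1`: 2 nM
Compound 2, `C[C@@H](Nc1nccc(Cl)c1NC(=O)CC#N)c1ccc(-c2cccc(F)c2C(F)(F)F)cc1`: 1.1 nM
Compound 3, `Cc1noc(-c2c(F)cccc2-c2ccc([C@@H](C)Nc3nccc(Cl)c3NC(=O)CC#N)cc2)n1`: 0.5 nM

Three compounds sharing one core were tested in an assay on CHO cells for displacement of a labelled ligand from B1 bradykinin receptor (Homo sapiens); on this read-out higher numbers stand for weaker inhibition and lower numbers for stronger inhibition. Compound 2 holds the second highest of the three numbers; a 1.8-fold lower number from compound 1 to compound 2 (0.26 log units; within the scatter) lies within the scatter, whereas a 2.2-fold lower number from compound 2 to compound 3 (0.34 log units; beyond the scatter) lies beyond it. Compound 4, `COC(=O)c1c(Cl)cccc1-c1ccc([C@@H](C)Nc2nccc(Cl)c2NC(=O)CC#N)cc1`, differs from compound 2 in one place: 3-chloro-2-(methoxycarbonyl)phenyl in place of 3-fluoro-2-(trifluoromethyl)phenyl on an aromatic carbon. Among the compounds with values here, two measured steps touch this same position in this assay: a 1.8-fold lower number from compound 1 to compound 2 (0.26 log units; within the scatter) changed little, while a 4.0-fold lower number from compound 1 to compound 3 (0.60 log units; beyond the scatter) brought a modest gain. Within the data shown here, the incoming chlorine and methoxycarbonyl have no measured counterpart, so no step beyond the scatter is expected in this assay. Compound 4 is therefore estimated at 1.5 nM, within 0.4 nM to 6 nM, which means an expected 1.4-fold higher number from compound 2 to compound 4 (0.13 log units; within the scatter).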

Compound 4, inhibition constant: 0.7 nM
Compound 4: middle estimate off by 2.1-fold (0.33 log units), on the high side; the measured number falls inside the stated range.
By their numbers in this assay, from the lowest: compounds 3, 4, 2 and 1 (each within the scatter of the next, the first and the last beyond it).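

In this assay, a ring carrying chlorine and methoxycarbonyl, with hydrogen-bond acceptors the outgoing ring lacks, is tolerated at this position: a 1.6-fold lower number from compound 2 to compound 4 (0.20 log units; within the scatter) stays within the scatter. Against the 2-cyano-3-fluorophenyl ring it brings a modest gain, a 2.9-fold lower number from compound 1 to compound 4 (0.46 log units; beyond the scatter), so a third replacement for that ring also gives a lower number. No available evidence accounts for this result. From the compounds shown here alone, two substituents change together here, so the share of chlorine and of methoxycarbonyl stays open. Going by these compounds, what a carboxylic acid or a primary amide would give in place of the methoxycarbonyl also stays open.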